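Methyl in place of cyclohexyl: an expected small step

The compounds below may be only part of what the source reports. "The series", "measured", "known", "first", "only" and "open" are said of these compounds alone.

In a functional assay on MCF7 cells (Homo sapiens) for inhibition, read by sulforhodamine B assay, with a stated time of 48 h (a lower number here means a stronger inhibitor of growth, a higher number a weaker inhibitor of growth), three compounds of the series have been measured so far. Compound 1 (`c1cc(C2CCCCC2)ccc1NC1=NCCO1`) gives 17500 nM. Compound 2 (`c1ccc(COc2ccc(NC3=NCCO3)cc2)cc1`) gives 11100 nM, and these two stand together at the high end of the set, within the scatter of each other. Compound 3 (`c1ccc(COc2cccc(NC3=NCCO3)c2)cc1`) gives 2600 nM, a number lower than that of compound 1 by a margin beyond the scatter.

The next compound to be read is compound 4 (`Cc1ccc(NC2=NCCO2)cc1`), which has methyl in place of cyclohexyl on an aromatic carbon. For the measured compounds named here, no pair of measured compounds differs in one place only, so the series offers no direct reading of such a change. Every measured compound carries a group larger than methyl, and the data show nothing about how a group this small behaves. A modest rise in the number in this assay is expected, close to the edge of the scatter, though no change beyond the scatter remains possible. The expected size of the change is a 1.7-fold higher number from compound 1 to compound 4 (0.23 log units; within the scatter). For compound 4 the estimated value is 30000 nM, with an expected range from 12000 nM to 80000 nM.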

Compound 4, concentration for 50% growth inhibition: 27000 nM
Estimate against measurement, compound 4: 1.1-fold (0.05 log units) above, and the stated range covers the measured number.
By their numbers in this assay, from the lowest: compound 3; then compounds 2, 1 and 4 (each within the scatter of the next, the first and the last beyond it).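

In this assay, for the compounds shown here, the pair of compound 1 and compound 4 is the first to differ in one place only, and it gives a 1.5-fold higher number from compound 1 to compound 4 (0.19 log units; within the scatter) for methyl in place of cyclohexyl on an aromatic carbon. At this position, with the rest of the core unchanged, a group of 6 heavy atoms carrying a six-membered non-aromatic ring and a single carbon are therefore not told apart, and the whole of that difference in size and ring stays inside the scatter. Nothing at hand bears on why the two groups read alike in this measurement.

The compounds shown leave open whether a group of another kind at this position, such as an amine, a carboxylic acid, a methoxy group or a longer chain, would move the number beyond the scatter, since both groups compared here are plain carbon groups with no hydrogen-bond donors or acceptors. Also open, as far as these compounds go, is how the bare core with hydrogen at this carbon would read against compound 4.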